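Taking the bromo group off compound 1

A few compounds are considered here, and "the series" means these few. Any claim that something is new, unique, unknown or untested is made for them only; others in the source may bear on it.

Values measured in an ADME assay on microsomes from liver (Rattus norvegicus) for metabolic stability, read by LC-MS, in the presence of a further agent that is not named here (a higher number here means faster removal of the compound, a lower number slower removal), are:

Compound 1 `Cc1ncc(C)n2nc(-c3ccn4cc(-c5ccc(Br)cc5)nc4n3)nc12` gives 15 mL.min-1.g-1
Compound 2 `Cc1ncc(C)n2nc(-c3ccc4nc(-c5ccccn5)[nH]c4c3)nc12` gives 11.1 mL.min-1.g-1
Compound 3 `Cc1ncc(C)n2nc(-c3ccc4nc(-c5ccco5)[nH]c4c3)nc12` gives 26.3 mL.min-1.g-1

Compound 1 at 15 mL.min-1.g-1 lies within the usual scatter of both compound 2 and compound 3, so its number cannot be told apart from either of theirs.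

Compound 4 `Cc1ncc(C)n2nc(-c3ccn4cc(-c5ccccc5)nc4n3)nc12` has not yet been measured. It differs from compound 1 in one place: hydrogen in place of bromo on an aromatic carbon that is, hydrogen in place of bromo on an aromatic carbon, para to a large group, so that 4-bromophenyl becomes phenyl.

Within the data shown here, only one measured step bears on this, and only loosely. The step of a 2.4-fold higher number from compound 2 to compound 3 (0.37 log units; beyond the scatter) has furan-2-yl in place of pyridin-2-yl on an aromatic carbon, which is a modest move and a different kind of exchange. Among the measured compounds shown here, no measured pair shows the loss of a bromo group. For the measured compounds named here, with that single modest step as the only guide, no step beyond the scatter is expected in this assay and no direction can be favoured with confidence. The estimated step is a 1.1-fold lower number from compound 1 to compound 4 (0.03 log units; within the scatter) and it is expected to stay within the scatter. The estimate for compound 4 is 14 mL.min-1.g-1 with an expected range of 7 mL.min-1.g-1 to 28 mL.min-1.g-1.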

Compound 4, intrinsic clearance in microsomes: 5.6 mL.min-1.g-1
Beside the measured number, compound 4's estimate is 2.5-fold (0.40 log units) above it; measured number below the stated range.
By their numbers in this assay, from the lowest: compounds 4, 2, 1 and 3 (each within the scatter of the next, the first and the last beyond it).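

In this assay, the loss of the bromo group gives a 2.7-fold lower number from compound 1 to compound 4 (0.43 log units; beyond the scatter), so this place on the 4-bromophenyl ring, para to a large group, is not indifferent to what it carries. Among these compounds, the change is small in atoms, a single bromine exchanged for hydrogen with no ring, donor, acceptor or charge entering or leaving, and yet its step lies beyond the scatter, whereas the only step readable before, a 2.4-fold higher number from compound 2 to compound 3 (0.37 log units; beyond the scatter), was an exchange of one whole ring for another on a different core and said nothing about this place. The data shown hold nothing that explains why the number falls when the bromo group leaves.

The compounds shown leave open whether the step is particular to bromo or would also be seen with a chloro, fluoro, methyl, methoxy or amine group at the same place. They also leave open whether the same exchange of bromo for hydrogen would move the number by a similar amount on the core of compound 2.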